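This account rests on a few compounds, and the source may have more. Where it says the series, first, only, none or still open, it means among the compounds named here.

Measured so far:
- compound 1 `CCCCOC(=O)C(=O)C(CC)NC(=O)C(CC(C)C)NC(=O)OCc1ccccc1`: 28000 nM
- compound 2 `CCOC(=O)C(=O)[C@H](CC)NC(=O)[C@H](CC(C)C)NC(=O)[C@H](CC(C)C)NS(=O)(=O)c1ccc2ccccc2c1`: 100000 nM

In a functional assay for inhibition, with Rattus norvegicus as the target, at pH 7.35 (a higher number here means a weaker inhibitor, a lower number a stronger inhibitor), compound 1 stands lowest of the two at 28000 nM. Compound 2 gives 100000 nM, and the gap from compound 1 lies beyond the scatter. Compound 3 `CCC(NC(=O)C(CC(C)C)NC(=O)OCc1ccccc1)C(=O)C(=O)NCCCc1ccccc1` is not yet measured. It differs from compound 1 by (3-phenylpropyl)amino in place of butoxy on a carbonyl carbon, with (3-phenylpropyl)amino in place of butoxy on a carbonyl carbon. Among the measured compounds shown here, no measured pair shows this change, so the expectation is tentative: a moderate move to a lower number in this assay. The expected change is a 3.5-fold lower number from compound 1 to compound 3 (0.54 log units; beyond the scatter). Compound 3 is estimated at 8000 nM, within a range of 1500 nM to 40000 nM.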

Compound 3, half-maximal inhibitory concentration: 100000 nM
For compound 3 the middle estimate is 13-fold (1.10 log units) below the measured one; measured number outside the range, above it.
By their numbers in this assay, from the lowest: compound 1; then compounds 2 and 3 (each within the scatter of the next).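

Among the compounds shown here, measured in this assay, (3-phenylpropyl)amino in place of butoxy on a carbonyl carbon gives a 3.6-fold higher number from compound 1 to compound 3 (0.55 log units; beyond the scatter) and is the first single-place comparison. This position therefore responds to the change, and the entering group, with its six-membered aromatic ring and hydrogen-bond donor, does not bring a lower number. No available measurement bears on the reason for this step. Still open, on these data alone, is whether a shorter amine such as ethylamino, or a carboxylic acid, on this carbonyl carbon would match or lower the number of compound 1.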